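Hydrogen in Place of Methyl on an Amide-Type Nitrogen

The compounds below may be only part of what the source reports. "The series", "measured", "known", "first", "only" and "open" are said of these compounds alone.

Among the measured compounds shown here, in a physicochemical assay for solubility, read by HPLC, in phosphate buffer, measured as kinetic solubility, at pH 7.4 (on this read-out higher numbers stand for higher solubility and lower numbers for lower solubility), compound 1 `NS(=O)(=O)c1ccc(-c2cc(C(=O)N3CCCCC3)nn2-c2ccc(Cl)cc2)cc1` gives 65900 nM and compound 2 `CN(C(=O)c1cc(-c2ccc(S(N)(=O)=O)cc2)n(-c2ccc(Cl)cc2)n1)C1CC1` gives 99600 nM so compound 2 stands within the scatter of compound 1, the only other number available. Compound 3 `NS(=O)(=O)c1ccc(-c2cc(C(=O)NC3CC3)nn2-c2ccc(Cl)cc2)cc1` is separated from compound 2 by a single change (hydrogen in place of methyl on an amide-type nitrogen) with hydrogen in place of methyl on an amide-type nitrogen, so that cyclopropyl(methyl)amino becomes cyclopropylamino. For the measured compounds named here, no measured step makes this exact change. Going by the values given here, the nearest evidence is the one step on the same carbonyl carbon (a 1.5-fold higher number from compound 1 to compound 2 (0.18 log units; within the scatter)) which put cyclopropyl(methyl)amino in place of piperidin-1-yl and stayed within the scatter. It is only an indirect guide, but it offers no sign of a large shift from a change at this place. No step beyond the scatter is therefore expected in this assay and the data do not firmly settle a direction. The expected step is small (a 1.3-fold lower number from compound 2 to compound 3 (0.12 log units; within the scatter)) and remains an estimate. For compound 3 the estimated value is 75000 nM with an expected range from 25000 nM to 150000 nM in this measurement.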

Compound 3, solubility: 72600 nM
Compound 3: middle estimate off by 1.0-fold (0.01 log units), on the high side, and the stated range covers the measured number.
By their numbers in this assay, from the lowest: compounds 1, 3 and 2 (each within the scatter of the next).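

The exchange of methyl for hydrogen on the amide-type nitrogen, which turns cyclopropyl(methyl)amino into cyclopropylamino, now has a direct reading in this assay, where it gives [ a 1.4-fold lower number from compound 2 to compound 3 (0.14 log units; within the scatter) ], so this single change, which leaves the amide hydrogen in place of the methyl, does not carry the number beyond the scatter. The same holds for the wider exchange on the carbonyl carbon, with cyclopropylamino in place of piperidin-1-yl giving [ a 1.1-fold higher number from compound 1 to compound 3 (0.04 log units; within the scatter) ], so all three amides shown, tertiary or bearing the amide hydrogen, lie within the scatter of one another in this assay. Nothing in the data explains this flat picture, and no measurement bears on why these changes leave the read-out within the scatter.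

The compounds shown leave open whether this holds only for the small saturated groups seen so far, or also for a group on the amide-type nitrogen that carries an amine or a carboxylic acid, or for a longer chain there. They also leave open whether the same exchange of methyl for hydrogen would stay within the scatter on a different core.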